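This account rests on a few compounds, and the source may have more. Where it says the series, first, only, none or still open, it means among the compounds named here.

Measured in an ADME assay on CCRF-CEM cells (Homo sapiens) for cytotoxicity, with a stated time of 5 days; a higher number here means a weaker inhibitor, a lower number a stronger inhibitor:
- compound 1 `COc1nc(NC2CC2)c2ncn([C@H]3C[C@H](N=[N+]=[N-])[C@@H](CO)O3)c2n1`: > 100000 nM (a limit)
- compound 2 `[N-]=[N+]=N[C@H]1C[C@H](n2cnc3c(NCCCCCO)nc(N)nc32)O[C@@H]1CO`: > 100000 nM (a limit)

Compound 2 gives no number, only (the limit of > 100000 nM in this assay, at which 2 of the 2 values shown sit). Compound 3 `[N-]=[N+]=N[C@H]1C[C@H](n2cnc3c(NCCO)nc(N)nc32)O[C@@H]1CO` differs from compound 2 by hydroxy in place of 3-hydroxypropyl on a saturated chain carbon, two bonds along the chain from a nitrogen on an aromatic ring. The (5-hydroxypentyl)amino group thus becomes (2-hydroxyethyl)amino. Among the measured compounds shown here, no measured step in this assay sizes this change, and the only guide is that compound 1 and compound 2 share the same limit. The expected change, a number no higher from compound 2 to compound 3 (the limit leaves the size open), is none beyond the scatter, with no direction expected. For compound 3 the estimated value is 100000 nM, with an expected range of 40000 nM to 150000 nM.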

Compound 3, half-maximal inhibitory concentration: > 100000 nM
Compound 3: no number, only a limit; the forecaster's own chance of this, stated with the estimate: 85%; the middle value sits exactly at the limit.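

Compound 2 and compound 3 both stand only as limits, so the step between them cannot be read: the limit of > 100000 nM in this assay, at which 3 of the 3 values shown sit.
Still open, on these data alone, is whether shortening the chain from (5-hydroxypentyl)amino to (2-hydroxyethyl)amino changes cytotoxicity at all.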